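Swapping a pyridine ring for a methoxyphenyl ring

The source may report more compounds than this note shows. Statements on the series, on what has been measured and on what is new or still open speak of the compounds shown alone.

Of the compounds shown here, three sharing one core have been tested in an assay on CHO cells for displacement of a labelled ligand from adenosine receptor A1 (Homo sapiens), read by scintillation counting, tested at 10 uM; a higher number here means more inhibition at the concentration tested (going by the name of the read-out), a lower number less inhibition. Compound 1 `CC(C)(C)Cc1csc(N)c1C(=O)c1cccc(Cl)c1` gives 2%. Compound 3 `CC(C)(C)Cc1c(Br)sc(N)c1C(=O)c1cccc(Cl)c1` carries a bromine where compound 1 carries a hydrogen. Compound 3 gives 1%. The step of a number 1 percentage points lower from compound 1 to compound 3 (within the scatter) is within the scatter. Compound 2 `CC(C)(C)Cc1c(-c2ccncc2)sc(N)c1C(=O)c1ccc(Cl)cc1` gives 1% in this assay, a value level with compound 3 at the digits shown and within the scatter of compound 1, so all three show almost no inhibition.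

Compound 4 `COc1ccc(-c2sc(N)c(C(=O)c3ccc(Cl)cc3)c2CC(C)(C)C)cc1` has not yet been measured. It differs from compound 2 in one place: 4-methoxyphenyl in place of pyridin-4-yl on an aromatic carbon. Among the compounds with values here, no measured step exchanges one aromatic ring for another, so the only guides are that the one step available, bromo for hydrogen, moved the number by an amount within the scatter, and that every compound so far shows almost no inhibition at the concentration tested. On that basis the expected change in this assay is small, namely a number 1 percentage points higher from compound 2 to compound 4 (within the scatter). Compound 4 is therefore estimated at 2% in this assay, with a range from -8% to 12% that allows for the usual scatter of such a measurement.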

Compound 4, a percentage reported as inhibition, at one concentration (the size of the read-out at that concentration, not a potency): 1%
Beside the measured number, compound 4's estimate is 1 percentage points above it, within the range that was stated.
By their numbers in this assay, from the lowest: compounds 2, 3, 4 and 1 (each within the scatter of the next).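

Putting 4-methoxyphenyl in place of pyridin-4-yl on this aromatic carbon, next to the ring sulfur, gives no change at the digits printed from compound 2 to compound 4 (within the scatter) in this assay. Within the data shown here, this is the first measured exchange of one aromatic ring for another at this position, and a larger ring of carbon only, carrying a methoxy group, reads the same as a ring holding a nitrogen, with compound 4 at 1% and so still showing almost no inhibition; a pair this close to zero can reveal a gain at this position but has almost no room to reveal a loss. No other measurement bears on this result, so the data offer no explanation of it.

Still open, as far as these compounds go, is whether any group on this carbon can lift the number clear of the scatter, for example a phenyl ring carrying a carboxylic acid or an amine, or a longer chain in place of the ring. Also open, from the compounds shown here alone, is whether changing the neopentyl group or the amino group of the shared core would move the reading at all.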